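The compounds below may be only part of what the source reports. "The series", "measured", "known", "first", "only" and "open" are said of these compounds alone.

Measured so far in a functional assay on the whole organism (arterial blood) with Rattus norvegicus as the target; a lower number here means that less compound is needed, a higher number that more compound is needed for the effect:
- compound 1 `Cc1nc2cnccc2n1C1CCN(C(=O)CC(c2ccccc2)c2ccccc2)CC1`: 0.41 mg/kg
- compound 2 `CCCC(CC(=O)N1CCC(Cn2c(C)nc3cnccc32)CC1)c1ccccc1`: 0.0079 mg/kg

Of these two compounds, compound 2 has the lower number, so less of it is needed for the effect, and the gap to compound 1 lies well beyond the usual scatter. Compound 3 `Cc1nc2cnccc2n1CC1CCN(C(=O)CC(C)(O)c2ccccc2)CC1` has not yet been measured. It carries 1-hydroxy-1-phenylethyl in place of 1-phenylbutyl on a saturated chain carbon bound to a carbonyl carbon. Among the measured compounds shown here, no measured pair shows the effect of this change, so any forecast is uncertain. For the measured compounds named here, compound 2 at 0.0079 mg/kg holds the lowest number so far, which leaves more room for a rise than for a fall. An expected 13-fold higher number from compound 2 to compound 3 (1.10 log units; beyond the scatter) therefore points upward, beyond the scatter. For compound 3 the estimated value is 0.1 mg/kg, with an expected range of 0.015 mg/kg to 0.7 mg/kg.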

Compound 3, dose for 50% inhibition: 0.043 mg/kg
The estimate for compound 3 lay 2.3-fold (0.37 log units) above the measured number; measured number inside the range.
By their numbers in this assay, from the lowest: compound 2; then compound 3; then compound 1.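

In this assay, putting 1-hydroxy-1-phenylethyl in place of 1-phenylbutyl on a saturated chain carbon bound to a carbonyl carbon gives a 5.4-fold higher number from compound 2 to compound 3 (0.74 log units; beyond the scatter). This shows that the number responds to the group at this position, yet the entering group, which brings a hydrogen-bond donor and a hydrogen-bond acceptor absent from 1-phenylbutyl, still leaves compound 3 at 0.043 mg/kg. Nothing measured here explains the size or direction of this step.

The swap alters the carbon chain and adds a hydroxyl group in a single step, so the compounds shown cannot separate these two changes. A plain 1-phenylethyl group would test the hydroxyl group's part, and an amine or a methoxy group in its place would show how much this position tolerates other groups.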